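This account rests on a few compounds, and the source may have more. Where it says the series, first, only, none or still open, it means among the compounds named here.

Of the compounds shown here, two built on a shared core have been measured in an assay on HEK293 cells for positive allosteric modulation of metabotropic glutamate receptor 5 (Homo sapiens), read by FLIPR, with a stated time of 1 h; on this read-out lower numbers stand for an effect already at smaller amounts and higher numbers for an effect only at larger amounts of compound. Compound 1 `O=C(C1CCC(F)(F)CC1)N1CCc2nc(C#Cc3ccccc3)sc2C1` gives 70 nM in this assay, and compound 2 `O=C(CC1CCOCC1)N1CCc2nc(C#Cc3ccccc3)sc2C1` gives 470 nM. For the measured compounds named here, the single measured step, a 6.7-fold higher number from compound 1 to compound 2 (0.83 log units; beyond the scatter), leaves compound 2 with the higher of the two numbers. Compound 3 `N#Cc1cccc(C(=O)N2CCc3nc(C#Cc4ccccc4)sc3C2)c1` differs from compound 2 in one place: 3-cyanophenyl in place of (oxan-4-yl)methyl on a carbonyl carbon. Going by the values given here, no measured step exchanges a non-aromatic group for an aromatic one on the carbonyl carbon; what the data show is only that a change at this carbonyl carbon can move the number well beyond the scatter, as a 6.7-fold higher number from compound 1 to compound 2 (0.83 log units; beyond the scatter) did. The step of a 3.1-fold lower number from compound 2 to compound 3 (0.50 log units; beyond the scatter) is expected to be modest and downward. Compound 3 is accordingly estimated at 150 nM, with a range from 40 nM to 600 nM that reflects the absence of a directly comparable step.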

Compound 3, half-maximal effective concentration: 71 nM
Beside the measured number, compound 3's estimate is 2.1-fold (0.32 log units) above it; low and high end bracket the measured number.
By their numbers in this assay, from the lowest: compounds 1 and 3 (each within the scatter of the next); then compound 2.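

In this assay, the only aromatic group shown on this carbonyl carbon, 3-cyanophenyl, gives a 6.6-fold lower number from compound 2 to compound 3 (0.82 log units; beyond the scatter) when it replaces (oxan-4-yl)methyl. Replacing 4,4-difluorocyclohexyl with the same group gives a 1.0-fold higher number from compound 1 to compound 3 (0.01 log units; within the scatter), so here an aromatic ring and a non-aromatic ring cannot be told apart on this read-out, while (oxan-4-yl)methyl stands apart from both. Nothing available accounts for this pattern.

The compounds shown do not separate the contribution of the nitrile from that of the benzene ring it sits on, so it remains open whether plain phenyl, or a phenyl carrying an amine in place of the nitrile, would match compound 3. From the compounds shown here alone, it is also open whether the methylene of (oxan-4-yl)methyl or its ring oxygen goes with the higher number of compound 2.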